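Chain length on a thiazolidine amide: the next step

This account rests on a few compounds, and the source may have more. Where it says the series, first, only, none or still open, it means among the compounds named here.

Measured so far:
compound 1, `CCCCCCCCNC(=O)[C@@H]1CSC(c2cc(OC)c(OC)c(OC)c2)N1`: 17100 nM
compound 2, `CCCCCCCCCCNC(=O)[C@@H]1CSC(c2cc(OC)c(OC)c(OC)c2)N1`: 14500 nM
compound 3, `CCCCCCCCCCCCNC(=O)[C@@H]1CSC(c2ccc(OC)c(OC)c2)N1`: 2900 nM

All three compounds were tested in a functional assay on cells (Homo sapiens) for antiproliferative activity, read by sulforhodamine B assay, with a stated time of 48 h; a higher number here means a weaker inhibitor, a lower number a stronger inhibitor. Compound 1 and compound 2 share one core and differ only in the length of the chain on the amide nitrogen: ethyl in place of hydrogen on a saturated chain carbon, eight bonds along the chain from an amide-type nitrogen. This change gave a 1.2-fold lower number from compound 1 to compound 2 (0.07 log units; within the scatter), so the two values are not distinguishable. Compound 3 is built on a different core, and the difference between the two cores is not broken down here. In this assay compound 3 gives 2900 nM, the lowest number of the three.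

Compound 4, `CCCCCCCCCCCCCCNC(=O)[C@@H]1CSC(c2ccc(OC)c(OC)c2)N1`, has not yet been measured. It relates to compound 3 as compound 2 relates to compound 1: ethyl in place of hydrogen on a saturated chain carbon, ten or more bonds along the chain from an amide-type nitrogen. The place of the change is worded differently in the two pairs, so this is the same kind of change rather than the same change. Since the earlier chain extension gave a 1.2-fold lower number from compound 1 to compound 2 (0.07 log units; within the scatter), a step within the scatter, compound 4 is expected to land close to compound 3, with the estimated step of a 1.2-fold lower number from compound 3 to compound 4 (0.06 log units; within the scatter). The estimate for compound 4 in this assay is 2500 nM, with a range from 1000 nM to 6500 nM.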

Compound 4, half-maximal inhibitory concentration: 1500 nM
Estimate against measurement, compound 4: 1.7-fold (0.22 log units) above; measured number inside the range.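

In this assay, ethyl in place of hydrogen on a saturated chain carbon, ten or more bonds along the chain from an amide-type nitrogen, gives a 1.9-fold lower number from compound 3 to compound 4 (0.29 log units; within the scatter), so the two values cannot be told apart. Set beside the earlier chain extension, the same kind of change shows no measurable difference between the two cores: the same change on two cores in this assay, a 1.2-fold lower number (0.07 log units; within the scatter) from compound 1 to compound 2 and a 1.9-fold lower number (0.29 log units; within the scatter) from compound 3 to compound 4, 1.6-fold (0.21 log units) apart, within the scatter of two such steps This suggests that, on these two cores, the change carries over with a similar small step, but it rests on only two pairs of compounds and does not show that chain length is without effect or that the same would hold on any other core.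

The compounds shown leave open what a longer chain than the one on compound 4 would do, and what would follow from an amine or a carboxylic acid at the far end of the chain. They also leave open what the difference between the two cores does on its own, as no pair shown carries the same chain on both cores.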